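Notes on the oxazole replacement at the ether chain

This account rests on a few compounds, and the source may have more. Where it says the series, first, only, none or still open, it means among the compounds named here.

The series is followed in a functional assay on HEK293 cells for agonist activity at G-protein coupled receptor 39 (Homo sapiens), read by scintillation proximity assay and inositol phosphate accumulation, with a stated time of 75 min, in the presence of a further agent that is not named here; on this read-out higher numbers stand for an effect only at larger amounts of compound and lower numbers for an effect already at smaller amounts. Compound 1 `C/C(=N\NC(=O)c1cc2ccccc2cc1O)c1ccc(N)cc1` gives 1100 nM. Compound 2 `Cc1cc(C)n(CCOC2CC(=O)Nc3c2c(C)nn3-c2ncnc3nc[nH]c23)n1` gives 16 nM. Compound 3 `Cc1nn(-c2ncnc3nc[nH]c23)c2c1C(c1ccc(OC(C)C)cc1)CC(=O)N2` gives 18 nM. Compound 2 has the lowest number of the three measured compounds; compound 3 stands nearest, and the step of a 1.1-fold higher number from compound 2 to compound 3 (0.05 log units; within the scatter) stays within the scatter, whereas compound 1 lies far higher, with a gap beyond the scatter.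

Compound 4 `Cc1noc(C)c1COC1CC(=O)Nc2c1c(C)nn2-c1ncnc2nc[nH]c12` is the next compound to be measured in this assay. Relative to compound 2 it carries 3,5-dimethyl-1,2-oxazol-4-yl in place of (3,5-dimethyl-1H-pyrazol-1-yl)methyl on a saturated chain carbon bound to an oxygen on a saturated carbon; the same difference, cut one bond further out, reads 2-(3,5-dimethyl-1H-pyrazol-1-yl)ethyl to (3,5-dimethyl-1,2-oxazol-4-yl)methyl.

Among the compounds with values here, no measured step touches this position. Within the data shown here, the only step available, from compound 2 to compound 3, exchanges a group on a saturated ring carbon and is within the scatter, so it offers no direct guide to a change on the saturated chain carbon. Both five-membered rings carry the same count of acceptors and no donors, and the shared core is kept intact. The expected step is therefore a 1.6-fold higher number from compound 2 to compound 4 (0.19 log units; within the scatter), a change not beyond the scatter, in either direction. Compound 4 is estimated at 25 nM, with a range from 8 nM to 80 nM.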

Compound 4, half-maximal effective concentration: 5 nM
For compound 4 the middle estimate is 5.0-fold (0.70 log units) above the measured one; measured number outside the range, below it.
By their numbers in this assay, from the lowest: compound 4; then compounds 2 and 3 (each within the scatter of the next); then compound 1.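

In this assay, the ether chain turns out to be sensitive to its terminal group: 3,5-dimethyl-1,2-oxazol-4-yl in place of (3,5-dimethyl-1H-pyrazol-1-yl)methyl gives a 3.2-fold lower number from compound 2 to compound 4 (0.51 log units; beyond the scatter), even though both groups carry one five-membered aromatic ring with 2 hetero atoms and the same counts of donors and acceptors. Compounds 2 and 3 could not be told apart, with a 1.1-fold higher number from compound 2 to compound 3 (0.05 log units; within the scatter), but (3,5-dimethyl-1,2-oxazol-4-yl)methoxy in place of 4-isopropoxyphenyl on the saturated ring carbon gives a 3.6-fold lower number from compound 3 to compound 4 (0.56 log units; beyond the scatter), so this group separates itself from both earlier substituents. No measurement is available that accounts for the shift.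

The same difference reads 2-(3,5-dimethyl-1H-pyrazol-1-yl)ethyl to (3,5-dimethyl-1,2-oxazol-4-yl)methyl, so ring and chain length change together, and the compounds shown do not separate the two; a 2-(3,5-dimethyl-1,2-oxazol-4-yl)ethyl group would be needed for that. Also open, on these data alone, is whether the step survives with an amine in place of the ether oxygen, or with the two methyl groups on the 1,2-oxazole removed.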